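The source may hold more compounds than are shown below. What is called first, only, known or untested is meant among the compounds shown, and "the series" means these compounds.

Compound 1 `FC(F)(F)c1cc(NC[C@H]2CCCN2)c2cn[nH]c2c1`: 55%
Compound 2 `O=C(O)c1cccc(CNc2cc(C(F)(F)F)cc3[nH]ncc23)c1`: 81%
Compound 3 `CNC(=O)c1cccc(CNc2cc(C(F)(F)F)cc3[nH]ncc23)c1`: 71%

In an assay for inhibition of Tryptophan 2,3-dioxygenase (Homo sapiens), with stated times of 10 min and 60 min, tested at 10 uM (on this read-out higher numbers stand for a stronger effect at the one concentration tested and lower numbers for a weaker effect), compound 3 gives 71%, the second highest of the three numbers. Its nearest neighbour is compound 2: the step of a number 10 percentage points lower from compound 2 to compound 3 (within the scatter) lies within the scatter, so the two values cannot be told apart. Compound 1 is the furthest away, and in this assay compound 1 gives 55%, a number that compound 3 exceeds beyond the scatter.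

Compound 4 `Nc1cccc(CNc2cc(C(F)(F)F)cc3[nH]ncc23)c1` has not yet been measured. It differs from compound 3 in one place: amino in place of methylcarbamoyl on an aromatic carbon. Among the compounds with values here, the only measured step that touches the same part of the molecule is the one from compound 2 to compound 3, where swapping one group on the carbonyl carbon for another moved the number by a number 10 percentage points lower from compound 2 to compound 3 (within the scatter), within the scatter. The new change is larger, since the whole methylcarbamoyl goes and only amino stays, so the past step is a weak guide. The expectation is therefore a step of a number 6 percentage points lower from compound 3 to compound 4 (within the scatter) in this assay, not beyond the scatter in either direction. Compound 4 is estimated at 65%, with a range from 45% to 85%.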

Compound 4, a percentage reported as inhibition, at one concentration (the size of the read-out at that concentration, not a potency): 68%
Compound 4: the middle estimate sits 3 percentage points below what was measured; low and high end bracket the measured number.
By their numbers in this assay, from the lowest: compound 1; then compounds 4, 3 and 2 (each within the scatter of the next, the first and the last beyond it).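

In this assay, the step is a number 3 percentage points lower from compound 3 to compound 4 (within the scatter), so the two compounds cannot be told apart, even though only a single heavy atom of the group on this aromatic carbon remains in compound 4. The change to amino from carboxy gives a number 13 percentage points lower from compound 2 to compound 4 (beyond the scatter), a modest step but the first at this aromatic carbon that lies beyond the scatter. The step of a number 13 percentage points higher from compound 1 to compound 4 (beyond the scatter) is also modest and beyond the scatter, and it shows that the amino-bearing 3-aminophenyl group in place of pyrrolidin-2-yl keeps a higher number.

No measurement shown explains why these numbers fall as they do. On these data alone, it remains open whether a hydroxy group or a nitrile on this aromatic carbon would give a number closer to that of compound 2 or to that of compound 4.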